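Ethyl for methylsulfanyl on the shared core

This account rests on a few compounds, and the source may have more. Where it says the series, first, only, none or still open, it means among the compounds named here.

In an ADME assay on a cell-free system (plasma, Homo sapiens) for protein binding, compound 3 `CSc1nc2nc(C)cc(Nc3ccc(C(F)(F)F)cc3)n2n1` gives 91.8% and compound 2 `CCc1nc2nc(C)cc(Nc3ccc(Cl)cc3)n2n1` gives 86.1% within the scatter of each other. Compound 1 `COCc1nc2nc(C)cc(Nc3ccc(C(F)(F)F)cc3)n2n1` gives 75.6% and stands further off. For the measured compounds named here, the one measured step, a 3.0-fold lower unbound fraction from compound 1 to compound 3 (0.47 log units; beyond the scatter) and beyond the scatter, is modest and changes the group on the same aromatic carbon.

Compound 4 `CCc1nc2nc(C)cc(Nc3ccc(C(F)(F)F)cc3)n2n1` differs from compound 3 in one place, with ethyl in place of methylsulfanyl on an aromatic carbon as the counted change: ethyl in place of methylsulfanyl on an aromatic carbon. Going by the values given here, no measured step makes this exchange. The measured step a 3.0-fold lower unbound fraction from compound 1 to compound 3 (0.47 log units; beyond the scatter) bears on it only as a guide to size at this place. Compound 2 carries the ethyl but differs from compound 4 elsewhere, and compound 2 gives 86.1%, which suggests that ethyl is compatible with high binding here. No step beyond the scatter is therefore expected, with at most a slight drift toward more free compound. The expected step is a 1.2-fold higher unbound fraction from compound 3 to compound 4 (0.09 log units; within the scatter) and stays within the scatter. For compound 4 the estimated value is 90% with an expected range from 83% to 95% in this series.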

Compound 4, plasma protein binding: 87.5%
Compound 4: middle estimate off by 1.3-fold (0.10 log units) (unbound fraction), on the low side; low and high end bracket the measured number.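

In this assay, for the compounds shown here, ethyl in place of methylsulfanyl on the aromatic carbon between two ring nitrogen atoms gives a 1.5-fold higher unbound fraction from compound 3 to compound 4 (0.18 log units; within the scatter) and thus no step past the scatter, even with the sulfur and the counted hydrogen-bond acceptor gone from this place. With ethyl held at this position, trifluoromethyl in place of chloro gives a 1.1-fold lower unbound fraction from compound 2 to compound 4 (0.05 log units; within the scatter) and methyl in place of methoxy on the saturated chain carbon gives a 2.0-fold lower unbound fraction from compound 1 to compound 4 (0.29 log units; within the scatter), so among the steps now printed only a 3.0-fold lower unbound fraction from compound 1 to compound 3 (0.47 log units; beyond the scatter) lies beyond the scatter. The data shown offer no measured reason for any of these steps.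

Open, from the compounds shown here alone, is how binding responds to an amine or a carboxylic acid on this aromatic carbon. A longer chain than ethyl at this place also remains untested among the compounds shown.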